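The source may hold more compounds than are shown below. What is called first, only, known or untested is meant among the compounds shown, and "the series" means these compounds.

Two compounds were tested in an ADME assay on Vero cells (Chlorocebus sabaeus) for cytotoxicity, read by MTT assay, with a stated time of 72 h; a lower number here means that less compound is tolerated, a higher number that more compound is tolerated. Compound 1 `CC/C(=C\c1ccc(Cl)cc1)C(=O)/C=C/c1ccc([N+](=O)[O-])cc1` gives 36000 nM in this assay. Compound 2 `COc1ccc(/C=C(\C)C(=O)/C=C/c2cccc(Br)c2)cc1` gives 153000 nM in this assay. Of the two numbers, compound 2 has the higher one, and the gap between the number of compound 2 and that of compound 1 lies beyond the usual scatter, so compound 2 is the better tolerated of the pair on these measurements.

Compound 3 `COc1ccc(/C=C(\C)C(=O)/C=C/c2ccccc2Cl)cc1` has not yet been measured in this assay. It differs from compound 2 in one place: 2-chlorophenyl in place of 3-bromophenyl on a double-bonded chain carbon bound to a double-bonded chain carbon. The shared core and the methoxy-bearing aryl side are kept; only the halogenated aryl group on the other end of the chain is exchanged.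

Going by the values given here, no measured pair in this set shares this kind of exchange, so there is no measured step to lean on. With one halogenated aryl group replaced by another halogenated aryl group of the same size, the step from compound 2 to compound 3 in this assay is expected to be small, with no clear direction beyond the scatter, as a 1.4-fold lower number from compound 2 to compound 3 (0.14 log units; within the scatter). Compound 3 is therefore estimated at 110000 nM, within a range from 40000 nM to 300000 nM.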

Compound 3, half-maximal cytotoxic concentration: 74300 nM
Estimate against measurement, compound 3: 1.5-fold (0.17 log units) above; low and high end bracket the measured number.
By their numbers in this assay, from the lowest: compound 1; then compound 3; then compound 2.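

In this assay, placing 2-chlorophenyl in the site held by 3-bromophenyl, on a double-bonded chain carbon bound to a double-bonded chain carbon, gives a 2.1-fold lower number from compound 2 to compound 3 (0.31 log units; beyond the scatter) as a modest change that lies beyond the usual scatter. Going by these compounds alone, this is the only measured step in the set, and it shows that the number at this place depends on which halogenated aryl group is present, even though the two groups match in heavy-atom count, aromatic ring, hydrogen-bond donors and acceptors, and net charge. No measured evidence bears on what lies behind this step.

The exchange alters the halogen and its location on the phenyl ring together, so the compounds shown cannot assign the step to either change alone. They also leave open how this assay would respond to a plain phenyl group at this place, or to an aryl group carrying an amine or a carboxylic acid, and whether the step seen here would hold on the other aryl side of the chain.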